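Swapping the dimethylbenzyl arm for a methoxyphenoxy arm

The source may report more compounds than this note shows. Statements on the series, on what has been measured and on what is new or still open speak of the compounds shown alone.

Measured compounds:
compound 1 `Cc1cc(C)cc(Cc2ccc3c(NCCCNCc4ccco4)ccnc3c2)c1` – 23 10^-6 cm/s
compound 2 `COc1ccc(F)cc1CNCCCNc1ccnc2cc(Oc3ccc(F)cc3)ccc12` – 317 10^-6 cm/s
compound 3 `COc1cccc(CNCCCNc2ccnc3cc(Cc4cc(C)cc(C)c4)ccc23)c1O` – 23 10^-6 cm/s

In an ADME assay for permeability, using PAMPA, with a stated time of 30 min, at pH 7.4 (on this read-out lower numbers stand for lower permeability and higher numbers for higher permeability), compound 1 gives 23 10^-6 cm/s, level with compound 3 at 23 10^-6 cm/s; together these are the lowest of the three numbers, while compound 2 at 317 10^-6 cm/s stands well above them. Compound 4 `COc1cccc(Oc2ccc3c(NCCCNCc4ccco4)ccnc3c2)c1` differs from compound 1 by 3-methoxyphenoxy in place of 3,5-dimethylbenzyl on an aromatic carbon. Within the data shown here, the only measured single step, no change at the digits printed from compound 1 to compound 3 (within the scatter), concerns the other end of the molecule and says little about this change. Compound 2 also carries a phenoxy group, but it differs from compound 1 in two places, so its higher number is only a hint. A rise is therefore expected, though with wide uncertainty; the expected step is a 2.6-fold higher number from compound 1 to compound 4 (0.42 log units; beyond the scatter). The estimate for compound 4 is 60 10^-6 cm/s, with a range from 20 10^-6 cm/s to 200 10^-6 cm/s.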

Compound 4, apparent permeability: 317 10^-6 cm/s
Compound 4: middle estimate off by 5.3-fold (0.72 log units), on the low side; the whole stated range lies below it.
By their numbers in this assay, from the lowest: compounds 1 and 3 (each within the scatter of the next); then compounds 2 and 4 (each within the scatter of the next).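

In this assay, 3-methoxyphenoxy in place of 3,5-dimethylbenzyl on this aromatic carbon gives a 14-fold higher number from compound 1 to compound 4 (1.14 log units; beyond the scatter), so the number answers strongly to this change. Among these compounds, the one earlier single step, at the other end of the molecule, gave no change at the digits printed from compound 1 to compound 3 (within the scatter). The two groups match in heavy-atom count, and each holds one six-membered aromatic ring of carbon only, but only 3-methoxyphenoxy carries hydrogen-bond acceptors. As far as these compounds go, whether the step follows the linking oxygen or the methoxy group stays open, and unsubstituted phenoxy or 3-methoxybenzyl at this carbon would separate the two. No measurement shown here explains the size of this step.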